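Chloro in place of hydrogen on the phenoxy ring

The compounds below may be only part of what the source reports. "The series", "measured", "known", "first", "only" and "open" are said of these compounds alone.

Compound 1 `Nc1ccccc1NC(=O)c1ccc(COc2ccccc2)cc1`: 5670 nM
Compound 2 `O=C(/C=C/c1ccc(CN2CCc3ccccc32)cc1)NO`: "not determined" (no result reported)
Compound 3 `Nc1ccccc1NC(=O)/C=C/c1ccc(CN2CCc3ccccc32)cc1`: > 32000 nM

Among the measured compounds shown here, in a functional assay on MGC-803 cells (Homo sapiens) for antiproliferative activity, read by CCK-8 assay, with a stated time of 72 h (on this read-out higher numbers stand for weaker inhibition and lower numbers for stronger inhibition), compound 1 gives 5670 nM, the only plain number among the three measured compounds. For compound 2 no result was reported in this assay. Compound 3 reaches only a limit of the assay, (the limit of > 32000 nM in this assay, at which 1 of the 3 values shown sits), so it cannot be placed against compound 1. No step between measured compounds exists here, and no cause can be drawn from them. Compound 4 `Nc1ccccc1NC(=O)c1ccc(COc2ccc(Cl)cc2)cc1` differs from compound 1 by chloro in place of hydrogen on an aromatic carbon. With nothing measured to guide the direction, the step from compound 1 is expected to stay within the usual scatter, a 1.4-fold lower number from compound 1 to compound 4 (0.15 log units; within the scatter). Compound 4 is therefore estimated at 4000 nM, between 1500 nM and 12000 nM.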

Compound 4, half-maximal inhibitory concentration: > 32000 nM
Compound 4: no number, only a limit; the forecaster's own chance of this, stated with the estimate: 5%; middle value at least 8.0-fold (0.90 log units) away from the limit.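

Chloro in place of hydrogen on the phenoxy ring, para to a large group, is not a neutral change in this assay: this single heavy atom brings an at least 5.6-fold higher number from compound 1 to compound 4 (0.75 log units; beyond the scatter). Among the compounds shown here, this is the first step that can be read at this position, and it shows that the activity of compound 1 depends on what sits there. Compound 4 reaches only a limit of the assay, so the full size of the step stays unknown: the limit of > 32000 nM in this assay, at which 2 of the 4 values shown sit.

From the compounds shown here alone, whether fluoro, methoxy or an amine at this position would weaken inhibition as chloro does remains open. So does whether chloro at another carbon of the phenoxy ring would have the same effect.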